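Moving the chlorine around the phenyl ring

This account rests on a few compounds, and the source may have more. Where it says the series, first, only, none or still open, it means among the compounds named here.

Measured compounds:
Compound 3 `Cc1nn(-c2nc(-c3ccc(Cl)c(Cl)c3)c(SC(C)C)s2)c(C(=O)O)c1-c1ccccc1Cl` gives 13100 nM in a functional assay on BJAB cells (Homo sapiens) for antiproliferative activity, with a stated time of 4 days; a lower number here means that less compound is needed, a higher number that more compound is needed for the effect.
Compound 1 `COc1cncc(-c2c(C)nn(-c3nc(-c4ccc(Cl)c(Cl)c4)c(SC(C)C)s3)c2C(=O)O)c1` gives 21000 nM.
Compound 2 `CC(=O)Nc1ccc(-c2c(C)nn(-c3nc(-c4ccc(Cl)c(Cl)c4)c(SC(C)C)s3)c2C(=O)O)cc1` gives 139000 nM.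

Compound 3 has the lowest number of the three, but compound 1 lies within the scatter of it, as a 1.6-fold lower number from compound 1 to compound 3 (0.20 log units; within the scatter) shows, while compound 2 is clearly apart, by an 11-fold lower number from compound 2 to compound 3 (1.03 log units; beyond the scatter). Compound 4 `Cc1nn(-c2nc(-c3ccc(Cl)c(Cl)c3)c(SC(C)C)s2)c(C(=O)O)c1-c1ccc(Cl)cc1` differs from compound 3 only in how the same atoms are joined: 4-chlorophenyl in place of 2-chlorophenyl on an aromatic carbon. For the measured compounds named here, no measured step swaps one chlorophenyl for another, so nothing directly bears on this change. Going by the values given here, the steps of a 6.6-fold higher number from compound 1 to compound 2 (0.82 log units; beyond the scatter) and an 11-fold lower number from compound 2 to compound 3 (1.03 log units; beyond the scatter) show that the aryl group at this position can matter, and the one compound bearing a group at the same ring position as the entering chlorine, compound 2, gave the highest number. Compound 4 is therefore expected to show a 2.1-fold higher number from compound 3 to compound 4 (0.33 log units; beyond the scatter), a slightly higher number, estimated at 28000 nM with a range of 9000 nM to 90000 nM.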

Compound 4, half-maximal effective concentration: 2500 nM
Compound 4: middle estimate off by 11-fold (1.05 log units), on the high side; the whole stated range lies above it.
By their numbers in this assay, from the lowest: compound 4; then compounds 3 and 1 (each within the scatter of the next); then compound 2.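

Within this assay, moving the chlorine alone gives a 5.2-fold lower number from compound 3 to compound 4 (0.72 log units; beyond the scatter) with no atom gained or lost, so its placement on the phenyl ring matters here. Chloro in place of acetamido gives a 56-fold lower number from compound 2 to compound 4 (1.75 log units; beyond the scatter) in the same placement, so the group itself also counts. 4-Chlorophenyl in place of 5-methoxypyridin-3-yl gives an 8.4-fold lower number from compound 1 to compound 4 (0.92 log units; beyond the scatter) and leaves compound 4 lowest of the four.

Nothing shown explains these differences. Going by these compounds, whether 3-chlorophenyl, 4-bromophenyl or 4-methylphenyl would match compound 4 stays open.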